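Aryl exchange on an aromatic nitrogen: cytotoxicity notes

The source may hold more compounds than are shown below. What is called first, only, known or untested is meant among the compounds shown, and "the series" means these compounds.

Compound 1 `COc1cc(OC)c(-n2cc(CO/N=C3\CC[C@]4(C)[C@@H](CC/C=C(\C)CC/C=C(\C)CCC=C(C)C)[C@](C)(O)CC[C@H]4C3(C)C)nn2)c(OC)c1` and compound 2 `CC(C)=CCC/C(C)=C/CC/C(C)=C/CC[C@@H]1[C@@]2(C)CC/C(=N\OCc3cn(-c4ccncc4)nn3)C(C)(C)[C@@H]2CC[C@@]1(C)O` share one core; compound 3 `COc1cc(OC)c(-n2cc(COc3ccc(/C=C4\C[C@]5(C)[C@@H](CC/C=C(\C)CC/C=C(\C)CCC=C(C)C)[C@](C)(O)CC[C@H]5C(C)(C)C4=O)cc3)nn2)c(OC)c1` and compound 4 `CC(C)=CCC/C(C)=C/CC/C(C)=C/CC[C@@H]1[C@@]2(C)C/C(=C\c3ccc(OCc4cn(-c5ccncc5)nn4)cc3)C(=O)C(C)(C)[C@@H]2CC[C@@]1(C)O` share another. How the core of compound 1 and the core of compound 3 differ is not broken down here.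

In a functional assay on HepG2 cells (Homo sapiens) for cytotoxicity, read by MTT assay, with a stated time of 48 h (on this read-out higher numbers stand for weaker inhibition and lower numbers for stronger inhibition), compound 1 gives 14100 nM, and compound 2 gives 22000 nM. The change separating them, (pyridin-4-yl in place of 2,4,6-trimethoxyphenyl on an aromatic nitrogen), made a 1.6-fold higher number from compound 1 to compound 2 (0.19 log units; within the scatter). In this assay compound 3 gives 57500 nM, the highest number of the three measured and beyond the scatter from both compound 1 and compound 2.

Compound 4 carries the same change on the core of compound 3: pyridin-4-yl in place of 2,4,6-trimethoxyphenyl on an aromatic nitrogen. The surroundings of the place are word for word the same as before, so this is the same change, with one measured instance to lean on. A step of similar size is expected from compound 3 to compound 4 in this assay, namely a 1.3-fold higher number from compound 3 to compound 4 (0.12 log units; within the scatter), because the earlier instance gave a 1.6-fold higher number from compound 1 to compound 2 (0.19 log units; within the scatter). The single reference point leaves the range wide. Compound 4 is accordingly expected to give about 75000 nM, somewhere between 30000 nM and 180000 nM.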

Compound 4, half-maximal inhibitory concentration: 105000 nM
Compound 4: the middle estimate sits 1.4-fold (0.15 log units) below what was measured; measured number inside the range.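

On the core of compound 3, pyridin-4-yl in place of 2,4,6-trimethoxyphenyl on an aromatic nitrogen gives a 1.8-fold higher number from compound 3 to compound 4 (0.26 log units; within the scatter) in this assay. Within these pairs, the step reads the same on both cores: the same change on two cores in this assay, a 1.6-fold higher number (0.19 log units; within the scatter) from compound 1 to compound 2 and a 1.8-fold higher number (0.26 log units; within the scatter) from compound 3 to compound 4, 1.2-fold (0.07 log units) apart, within the scatter of two such steps. This supports carrying the step between the core of compound 1 and the core of compound 3, but each step lies within the scatter, so neither pair establishes that the exchange itself moves the number, and agreement on these cores says nothing about any other core.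

The compounds shown carry only 2,4,6-trimethoxyphenyl and pyridin-4-yl at this place, leaving open how a phenyl ring bearing a carboxylic acid or an amine, pyridin-3-yl, or a longer alkyl chain on the same aromatic nitrogen would read in this assay. Also open, going by these compounds, is whether the agreement between the steps would persist for such groups on either core.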